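Tolerance of a Piperidine Ring Variant in Cells

The compounds below may be only part of what the source reports. "The series", "measured", "known", "first", "only" and "open" are said of these compounds alone.

Compound 1: `NCC(O)CNc1cc(N2CCCc3ccccc3C2)nc2ccccc12` — 21000 nM
Compound 2: `NCCNc1cc(N2CCCc3ccccc3C2)nc2cc(Cl)ccc12` — 7500 nM
Compound 3: `Cc1ccc2nc(N3CCCc4ccc(F)cc4C3)cc(NCCN)c2c1` — > 3200 nM

Of the compounds shown here, three sharing one core have been tested in an ADME assay on HEp-2 cells (Homo sapiens) for cytotoxicity, read by CCK-8 assay, with a stated time of 5 days; a higher number here means that more compound is tolerated, a lower number that less compound is tolerated. Compound 1 gives 21000 nM and compound 2 gives 7500 nM in this assay. For compound 3 the result is only a limit of the assay, > 3200 nM; this is where compound 3 stands, and the evidence is the limit of > 3200 nM in this assay, at which 1 of the 3 values shown sits. Within the data shown here, none of these three differ from one another in a single place, so no measured step can be drawn among them.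

Compound 4 is `Cc1ccc2nc(N3CCCc4ccc(F)cc4C3)cc(NCC3CCCCN3)c2c1`. It differs from compound 3 by piperidin-2-yl in place of aminomethyl on a saturated chain carbon bound to a nitrogen on an aromatic ring. Among the measured compounds shown here, no measured pair shows the effect of such a change. He expects the step from compound 3 to compound 4 in this assay to be small, at most a modest move toward less compound tolerated, and it may well stay within the scatter: a step that the limit leaves unreadable from compound 3 to compound 4. He estimates compound 4 at 5000 nM in this assay, with a range from 1500 nM to 20000 nM.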

Compound 4, half-maximal cytotoxic concentration: 23000 nM
Beside the measured number, compound 4's estimate is 4.6-fold (0.66 log units) below it; measured number above the stated range.
By their numbers in this assay, from the lowest: compound 2; then compounds 1 and 4 (each within the scatter of the next).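

The step between compound 3 and compound 4 cannot be read in this assay, because compound 3 has only a limit of the assay: the limit of > 3200 nM in this assay, at which 1 of the 4 values shown sits.

The compounds shown leave open how far piperidin-2-yl in place of aminomethyl shifts tolerance, as no pair with two readable values carries this change.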